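This account rests on a few compounds, and the source may have more. Where it says the series, first, only, none or still open, it means among the compounds named here.

Measured so far in a functional assay on PC-12 cells (Rattus norvegicus) for cytotoxicity, read by MTT assay, with stated times of 3 h and 2 h, tested at 10 uM; on this read-out higher numbers stand for a stronger effect at the one concentration tested and lower numbers for a weaker effect:
compound 1 `O=C(CCCCC1CCSS1)NCc1cn(CCCOc2ccc3cc(-c4ccccc4)c(=O)oc3c2)nn1` gives 29.1%
compound 2 `COc1ccc(-c2cc3ccc(OCCCn4cc(CNC(=O)CCCCC5CCSS5)nn4)cc3oc2=O)cc1` gives 57.6%
compound 3 `O=C(CCCCC1CCSS1)NCc1cn(CCCCOc2ccc3cc(-c4ccccc4)c(=O)oc3c2)nn1` gives 30.5%

Compound 1 and compound 2 differ by methoxy in place of hydrogen on an aromatic carbon, and this change made a step of a number 28.5 percentage points higher from compound 1 to compound 2 (beyond the scatter). The difference between the core of compound 1 and the core of compound 3 is not broken down here; the two values of compound 1 and compound 3 lie within the scatter of each other. The value of compound 2 stands beyond the scatter above that of compound 3.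

Compound 4 `COc1ccc(-c2cc3ccc(OCCCCn4cc(CNC(=O)CCCCC5CCSS5)nn4)cc3oc2=O)cc1` is not yet measured. It differs from compound 3 by methoxy in place of hydrogen on an aromatic carbon, the same change as that between compound 1 and compound 2. For compound 4 the expected step in this assay is a number 27.5 percentage points higher from compound 3 to compound 4 (beyond the scatter), set beside the earlier one. This rests on compound 3 giving 30.5%, a starting point within the scatter of the value of compound 1 at 29.1%, so a step of like size is assumed. Compound 4 is accordingly estimated at 58%, expected to fall between 40% and 75%.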

Compound 4, a percentage reported as activity, at one concentration (the size of the read-out at that concentration, not a potency): 48.6%
Estimate against measurement, compound 4: 9.4 percentage points above, within the range that was stated.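

In this assay, the change from phenyl to 4-methoxyphenyl again gives a higher number on the second core, with a step of a number 18.1 percentage points higher from compound 3 to compound 4 (beyond the scatter). Set beside the earlier step, the two do not separate: the same change on two cores in this assay, a number 28.5 percentage points higher (beyond the scatter) from compound 1 to compound 2 and a number 18.1 percentage points higher (beyond the scatter) from compound 3 to compound 4, 10.4 percentage points apart, within the scatter of two such steps. This shows the change carrying over between these two cores in direction and, within the scatter, in size, but it rests on one pair per core and on a single concentration, so it shows neither a general rule for the series nor any difference in potency, and it gives no reason for the step.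

Still open, as far as these compounds go, is whether a step of like size appears on a core with a longer chain than that of compound 4. Also open, from the compounds shown here alone, is whether another group in place of methoxy, such as hydroxy, fluorine or an amine, gives a step in the same direction on both cores.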